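Methoxy for Methyl on the Phenyl of Compound 2

The compounds below may be only part of what the source reports. "The series", "measured", "known", "first", "only" and "open" are said of these compounds alone.

Of the compounds shown here, three sharing one core have so far been tested in a functional assay, read by spectrophotometry, with a stated time of 15 min, tested at 40 ug/mL; on this read-out lower numbers stand for a weaker effect and higher numbers for a stronger effect at the one concentration tested. Compound 1 `Fc1ccc(-c2csc(N/N=C/c3ccc(Cl)cc3Cl)n2)cc1` gives 93.3%, compound 2 `Cc1ccc(-c2csc(N/N=C/c3ccc(Cl)cc3Cl)n2)cc1` gives 86.2%, and compound 3 `COC(=O)c1cc(-c2csc(N/N=C/c3ccc(Cl)cc3Cl)n2)ccc1OCc1ccccc1` gives 37.2%. Among the compounds with values here, compound 2 thus stands second of the three: its nearest neighbour is compound 1, separated by a step of a number 7.1 percentage points lower from compound 1 to compound 2 (within the scatter), which is within the scatter, while compound 3 lies far below it, beyond the scatter, though compound 3 differs from compound 2 in more than one place and therefore offers no single step.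

Compound 4 `COc1ccc(-c2csc(N/N=C/c3ccc(Cl)cc3Cl)n2)cc1` differs from compound 2 in one place: methoxy in place of methyl on an aromatic carbon. Within the data shown here, the only measured step that bears on this change is the one from compound 1 to compound 2, also a swap of one small group on the same aromatic carbon, and it read a number 7.1 percentage points lower from compound 1 to compound 2 (within the scatter). On that basis no step beyond the scatter is expected in this assay; the expected step is a number 4.2 percentage points lower from compound 2 to compound 4 (within the scatter). Compound 4 is therefore estimated at 82%, with a range from 64% to 95%.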

Compound 4, a percentage reported as inhibition, at one concentration (the size of the read-out at that concentration, not a potency): 69.5%
The estimate for compound 4 lay 12.5 percentage points above the measured number, and the stated range covers the measured number.
By their numbers in this assay, from the lowest: compound 3; then compound 4; then compounds 2 and 1 (each within the scatter of the next).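

In this assay this place on the aromatic ring turns out to respond to the group it carries, which the swap of methyl for fluoro had not shown: methoxy in place of methyl gives a number 16.7 percentage points lower from compound 2 to compound 4 (beyond the scatter) and methoxy in place of fluoro gives a number 23.8 percentage points lower from compound 1 to compound 4 (beyond the scatter) as the two steps that now stand. Methoxy, which enters with two heavy atoms and one hydrogen-bond acceptor, is thus the first of these small groups on this carbon to separate from the others, while fluoro and methyl stay within the scatter of each other. Nothing measured here accounts for this difference.

On these data alone, whether the lower number follows the oxygen or the added heavy atom stays open. A hydroxyl or an ethyl group on the same carbon would set those two apart.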